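A few compounds are considered here, and "the series" means these few. Any claim that something is new, unique, unknown or untested is made for them only; others in the source may bear on it.

Compound 1 `COc1ccc(CS(=O)(=O)/C=C/c2c(OC)cccc2OC)c(N)c1`: 750 nM in a functional assay on K562 cells (Homo sapiens) for cytotoxicity, read by trypan blue exclusion, with a stated time of 96 h; a higher number here means a weaker inhibitor, a lower number a stronger inhibitor
Compound 2 `COC(=O)C(Nc1cc(CS(=O)(=O)/C=C/c2c(OC)cc(OC)cc2OC)ccc1OC)c1ccc(Br)cc1`: 200 nM in this assay

Compound 2 gives the lowest of the two numbers in this assay; its nearest neighbour is compound 1, whose number is higher by a margin beyond the usual scatter of repeated measurements, so compound 2 is the stronger inhibitor of the two. Compound 3 `COc1ccc(C(Nc2cc(CS(=O)(=O)/C=C/c3c(OC)cc(OC)cc3OC)ccc2OC)C(=O)O)cc1` has not yet been measured. It differs from compound 2 in one place: carboxy(4-methoxyphenyl)methyl in place of (4-bromophenyl)(methoxycarbonyl)methyl on a nitrogen on an aromatic ring. For the measured compounds named here, no two measured compounds differ in only a single place, so there is no measured step of this kind to lean on for the change. The change is expected to give a modest step in this assay toward a higher number, of the size a 3.0-fold higher number from compound 2 to compound 3 (0.48 log units; beyond the scatter), though a step within the scatter would not be surprising. Compound 3 is therefore expected to give about 600 nM in this assay, with a likely range from 150 nM to 3000 nM.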

Compound 3, half-maximal inhibitory concentration: 15 nM
Estimate against measurement, compound 3: 40-fold (1.60 log units) above; the whole stated range lies above it.
By their numbers in this assay, from the lowest: compound 3; then compound 2; then compound 1.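

In this assay, for the compounds shown here, carboxy(4-methoxyphenyl)methyl in place of (4-bromophenyl)(methoxycarbonyl)methyl gives a 13-fold lower number from compound 2 to compound 3 (1.12 log units; beyond the scatter) and this is the first single-place change that can be read in this set. It shows that the group on this nitrogen can move the number strongly, even though both groups have the same count of heavy atoms and one aromatic ring. No measurement here explains the size of this step.

The change swaps two features at once, the bromine for a methoxy group and the methyl ester for a carboxylic acid, so the compounds shown leave open which of them accounts for the step. A 4-bromophenyl group paired with the carboxylic acid would begin to separate the two, and a primary amide in place of the acid would test how much this position depends on the acid itself.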